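Swapping a chloro for a fluoro on a benzoxazole acid

A few compounds are considered here, and "the series" means these few. Any claim that something is new, unique, unknown or untested is made for them only; others in the source may bear on it.

Of the compounds shown here, three have been tested in an ADME assay on the whole organism (Macaca fascicularis) for pharmacokinetics, read by LC-MS, using cassette dosing, at a dose of 1 mg/kg by the oral route; on this read-out lower numbers stand for lower exposure and higher numbers for higher exposure at the dose given. Compound 1, `CCCCN(c1nc2c(NC(C)=O)cccc2o1)[C@H](C)c1ccc(-c2ccccc2-c2nnn[nH]2)cc1`, gives 41.6 ng.h/mL in this assay. Compound 2, `C[C@H](c1ccc(-c2cc(F)ccc2-c2nc(=O)o[nH]2)cc1)N(CC1CC1)c1nc2c(C(=O)O)cccc2o1`, gives 4410 ng.h/mL. Compound 3, `CCCCN(c1nc2c(C(=O)O)cccc2o1)[C@H](C)c1ccc(-c2cc(Cl)ccc2-c2nc(=O)o[nH]2)cc1`, gives 1040 ng.h/mL, which places it second highest of the three: compound 2 lies above it by more than the usual scatter, and compound 1 lies far below it.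

Compound 4, `CCCCN(c1nc2c(C(=O)O)cccc2o1)[C@H](C)c1ccc(-c2cc(F)ccc2-c2nc(=O)o[nH]2)cc1`, has not yet been measured. It differs from compound 3 in one place: fluoro in place of chloro on an aromatic carbon. Within the data shown here, compound 2 also carries a fluoro at that position, yet it differs from compound 4 elsewhere as well, so no single step gives the size of this swap.

The step of a 1.5-fold higher number from compound 3 to compound 4 (0.19 log units; within the scatter) is expected to be small, upward, and not clearly beyond the scatter. Compound 4 is estimated at 1600 ng.h/mL, with a range from 600 ng.h/mL to 4500 ng.h/mL.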

Compound 4, area under the concentration-time curve: 1630 ng.h/mL
Estimate against measurement, compound 4: 1.0-fold (0.01 log units) below; the measured number falls inside the stated range.
By their numbers in this assay, from the lowest: compound 1; then compounds 3 and 4 (each within the scatter of the next); then compound 2.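

In this assay, fluoro in place of chloro, on the carbon meta to a large group and para to a group of 6 heavy atoms, gives a 1.6-fold higher number from compound 3 to compound 4 (0.20 log units; within the scatter), so this one pair does not separate the two halogens at this position. With fluoro held in place, propyl in place of cyclopropyl gives a 2.7-fold lower number from compound 2 to compound 4 (0.43 log units; beyond the scatter), so in this pair a change in the chain on the nitrogen, unlike the halogen swap, reaches beyond the scatter. Nothing available here explains either step.

From the compounds shown here alone, whether a methyl, a methoxy or a nitrile on that same carbon would shift exposure beyond the scatter remains open. So does whether an ethyl or a longer chain on the nitrogen would extend the chain step, and compound 1 differs from the others in too many places to help.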